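This account rests on a few compounds, and the source may have more. Where it says the series, first, only, none or still open, it means among the compounds named here.

Measured compounds and their values:
- compound 1, `O=C(/C=C/c1cccc(NC(=O)c2ccccc2Cl)c1)c1nc2ccccc2[nH]1`: 1280 nM
- compound 2, `O=C(Nc1cccc(/C=C/C(=O)c2nc3ccccc3[nH]2)c1)c1ccc(Cl)cc1`: 2270 nM

In a functional assay on HCT-116 cells (Homo sapiens) for antiproliferative activity, read by MTT assay, with a stated time of 48 h (a lower number here means a stronger inhibitor, a higher number a weaker inhibitor), compound 2 gives the highest of the two numbers shown. Its nearest neighbour is compound 1, and the step of a 1.8-fold higher number from compound 1 to compound 2 (0.25 log units; within the scatter) lies within the scatter, so the two compounds cannot be ordered on these numbers.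

Compound 3, `O=C(/C=C/c1cccc(NC(=O)c2ccccc2Br)c1)c1nc2ccccc2[nH]1`, is not yet measured. It differs from compound 2 by 2-bromophenyl in place of 4-chlorophenyl on a carbonyl carbon. This change combines two things: the halogen returns to the position it holds in compound 1, and chlorine is exchanged for bromine. Among the measured compounds shown here, the only measured step that bears on it is a 1.8-fold higher number from compound 1 to compound 2 (0.25 log units; within the scatter), which moved the chlorine between these two positions without a change beyond the scatter. For the measured compounds named here, no measured step shows what exchanging chlorine for bromine does, so that part carries no evidence either way.

The expectation for compound 3 is therefore a number close to that of compound 1 and of compound 2, with a step of a 1.7-fold lower number from compound 2 to compound 3 (0.24 log units; within the scatter) that stays within the scatter. The estimate for compound 3 is 1300 nM, with a range from 500 nM to 3500 nM.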

Compound 3, half-maximal inhibitory concentration: 1680 nM
Beside the measured number, compound 3's estimate is 1.3-fold (0.11 log units) below it; low and high end bracket the measured number.
By their numbers in this assay, from the lowest: compounds 1, 3 and 2 (each within the scatter of the next).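

In this assay, exchanging chlorine for bromine with the halogen kept in the same place gives a 1.3-fold higher number from compound 1 to compound 3 (0.12 log units; within the scatter), so this first direct look at the halogen's identity shows a change no larger than repeat measurements would produce. The change that alters both the halogen and its place, 2-bromophenyl in place of 4-chlorophenyl on a carbonyl carbon, gives a 1.4-fold lower number from compound 2 to compound 3 (0.13 log units; within the scatter) and also stays within the scatter, so all three compounds sit together and cannot be ordered, and neither chlorine against bromine nor the two halogen placements shown separates them in this assay. Nothing measured on these compounds offers an explanation for how closely their numbers agree.

The compounds shown leave open whether 4-bromophenyl, which would complete the set of two halogens in two places, would also fall with the others. They also leave open whether a phenyl ring carrying something other than chlorine or bromine, such as a fluorine, a methoxy group, an amine or a carboxylic acid, would move the number beyond the scatter.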